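Swapping an indole for a dimethylphenyl on a shared core

The compounds below may be only part of what the source reports. "The series", "measured", "known", "first", "only" and "open" are said of these compounds alone.

Measured so far:
Compound 1, `Cn1ccc2cc(-c3cc4nccc(-c5ccc(F)cc5)n4n3)ccc21`: 5210 nM
Compound 2, `COc1cc(-c2ccnc3cc(-c4ccc5cc[nH]c5c4)nn23)cc(OC)c1OC`: 125 nM

For the measured compounds named here, in a functional assay on HeLa cells (Homo sapiens) for inhibition, read by CCK-8 assay, with a stated time of 48 h (a higher number here means a weaker inhibitor, a lower number a stronger inhibitor), compound 2 gives 125 nM, the lowest of the two numbers so far, while compound 1 gives 5210 nM, a gap well beyond the usual scatter. Compound 3, `COc1cc(-c2ccnc3cc(-c4ccc(C)c(C)c4)nn23)cc(OC)c1OC`, has not yet been tested. It differs from compound 2 in one place: 3,4-dimethylphenyl in place of 1H-indol-6-yl on an aromatic carbon. Going by the values given here, no pair of measured compounds shows this exact change, so the size of the step can only be guessed. With a single measured neighbour to lean on, the expectation is a moderate loss rather than a gain, with compound 2 at 125 nM as the anchor. The step from compound 2 to compound 3 in this assay is estimated at a 4.0-fold higher number from compound 2 to compound 3 (0.60 log units; beyond the scatter). Compound 3 is therefore expected to give about 500 nM, somewhere between 100 nM and 2500 nM.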

Compound 3, half-maximal inhibitory concentration: 241 nM
Beside the measured number, compound 3's estimate is 2.1-fold (0.32 log units) above it, within the range that was stated.
By their numbers in this assay, from the lowest: compounds 2 and 3 (each within the scatter of the next); then compound 1.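

On the aromatic carbon of the five-membered ring, the 1H-indol-6-yl group of compound 2 can give way to the 3,4-dimethylphenyl group, with a step of a 1.9-fold higher number from compound 2 to compound 3 (0.29 log units; within the scatter) in this assay. This change removes the five-membered ring and the one hydrogen-bond donor of the group, yet the two numbers cannot be told apart, so neither feature is needed at this position for activity in the range of compound 2 in this assay. No measurement shown explains this result.

Going by these compounds, it remains open how this position would respond to a plain phenyl, or to a phenyl carrying an amine or a carboxylic acid. It is also unknown whether one methyl group alone, at either of the two places it occupies in compound 3, would give a similar number.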